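Vinyl to methylsulfanyl on a homocysteine-like chain

A few compounds are considered here, and "the series" means these few. Any claim that something is new, unique, unknown or untested is made for them only; others in the source may bear on it.

Compound 1 `NC(CCSc1ccccc1C(=O)O)C(=O)O`: 42.5%
Compound 2 `C=CCSCCC(N)C(=O)O`: 0%

In an assay on isolated protein for inhibition of betaine--homocysteine S-methyltransferase 1 (Homo sapiens), tested at 20 uM (a lower number here means less inhibition, a higher number more inhibition at the concentration tested (going by the name of the read-out)), compound 2 gives 0%, the lowest of the two numbers, while compound 1 gives 42.5%, a gap beyond the scatter. Compound 3 `CSCSCCC(N)C(=O)O` is not yet measured. It differs from compound 2 by methylsulfanyl in place of vinyl on a saturated chain carbon bound to a sulfur. Among the measured compounds shown here, no measured pair shows this change, so the expected step from compound 2 to compound 3 in this assay is small, a number 6 percentage points higher from compound 2 to compound 3 (within the scatter), if any beyond the scatter. Compound 3 is estimated at 6%, within -8% to 25%.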

Compound 3, a percentage reported as inhibition, at one concentration (the size of the read-out at that concentration, not a potency): 20.5%
Estimate against measurement, compound 3: 14.5 percentage points below, within the range that was stated.
By their numbers in this assay, from the lowest: compound 2; then compound 3; then compound 1.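

In this assay, among the compounds shown here, methylsulfanyl in place of vinyl on a saturated chain carbon bound to a sulfur gives a number 20.5 percentage points higher from compound 2 to compound 3 (beyond the scatter) and is the first single change that can be read here. It shows that the read-out responds to the group at this place, which compounds 1 and 2 alone, differing in more than one place, could not show. Nothing at hand says why the step arises. Still open, on these data alone, is whether the sulfur of methylsulfanyl matters, which a methoxy group or a propyl group at this place would address. A longer chain bearing sulfur is equally untested among the compounds shown.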